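From 2-Bromophenyl to 2-Fluorophenyl: An Expected Small Step

A few compounds are considered here, and "the series" means these few. Any claim that something is new, unique, unknown or untested is made for them only; others in the source may bear on it.

In a toxicity assay on cells (Macrophage, Mus musculus, strain BALB/c) for cytotoxicity, read by MTT assay (on this read-out higher numbers stand for weaker inhibition and lower numbers for stronger inhibition), compound 1 (`COc1cc(O)cc(O)c1C(=O)/C=C/c1ccc(C)cc1`) gives 16500 nM and compound 2 (`COc1cc(O)cc(O)c1C(=O)/C=C/c1ccccc1Br`) gives 14600 nM. Among the compounds with values here, compound 2 therefore stands level with compound 1, its only measured neighbour, within the usual scatter. Compound 3 (`COc1cc(O)cc(O)c1C(=O)/C=C/c1ccccc1F`) departs from compound 2 at a single place: fluoro in place of bromo on an aromatic carbon. This puts fluoro in place of bromo on an aromatic carbon, ortho to a large group. Within the data shown here, only one measured step bears on this change, a 1.1-fold lower number from compound 1 to compound 2 (0.05 log units; within the scatter), and it stays within the scatter. Among the measured compounds shown here, that step replaces 4-methylphenyl with 2-bromophenyl, so no measured pair exchanges bromo for fluoro directly. No shift beyond the scatter is therefore expected in this assay, and no direction can be favoured. The expected change is small, a 1.0-fold higher number from compound 2 to compound 3 (0.01 log units; within the scatter). Compound 3 is estimated at 15000 nM, with an expected range from 7000 nM to 32000 nM.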

Compound 3, half-maximal inhibitory concentration: 16000 nM
Estimate against measurement, compound 3: 1.1-fold (0.03 log units) below; the range from low to high includes it.
By their numbers in this assay, from the lowest: compounds 2, 3 and 1 (each within the scatter of the next).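

In this assay, the exchange of bromo for fluoro on an aromatic carbon, ortho to a large group, now has a direct measured pair, with a 1.1-fold higher number from compound 2 to compound 3 (0.04 log units; within the scatter) as its step. The 2-fluorophenyl group also stands level with 4-methylphenyl, with a 1.0-fold lower number from compound 1 to compound 3 (0.01 log units; within the scatter) as the step, so 4-methylphenyl, 2-bromophenyl and 2-fluorophenyl cannot be told apart on this read-out. Nothing measured on these compounds explains why their numbers stay level.

On these data alone, it remains open whether an amine or a carboxylic acid in place of the halogen would move the number beyond the scatter. The compounds shown also leave open whether fluoro or bromo on another aromatic carbon of this ring would stay level with these three compounds.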